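A trifluoromethyl step from compound 2 to compound 4

The compounds below may be only part of what the source reports. "The series", "measured", "known", "first", "only" and "open" are said of these compounds alone.

Measured so far in a functional assay on HepG2 cells (Homo sapiens) for inhibition, read by sulforhodamine B assay, with a stated time of 74 h (on this read-out lower numbers stand for stronger inhibition and higher numbers for weaker inhibition), each entry a limit and not a number:
Compound 1 (`CS(=O)(=O)N1C(=O)COC12C=CC(=O)C=C2`): > 10000 nM
Compound 2 (`O=C1C=CC2(C=C1)OCC(=O)N2S(=O)(=O)c1ccccc1`): > 10000 nM
Compound 3 (`O=C1C=CC2(C=C1)OCC(=O)N2S(=O)(=O)c1ccccc1OC(F)(F)F`): > 10000 nM

Compound 2 reads > 10000 nM and this is a limit, not a number.

The next compound, compound 4 (`O=C1C=CC2(C=C1)OCC(=O)N2S(=O)(=O)c1ccc(C(F)(F)F)cc1`), differs from compound 2 in one place: trifluoromethyl in place of hydrogen on an aromatic carbon (trifluoromethyl in place of hydrogen on an aromatic carbon, para to a large group).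

For the measured compounds named here, two measured steps bear on this change. The closer one is a step that the two limits leave unreadable from compound 2 to compound 3, which also replaces hydrogen on an aromatic carbon. The other is a step that the two limits leave unreadable from compound 1 to compound 2, made at the sulfonyl sulfur. Neither size can be read because of the limit of > 10000 nM in this assay, at which 3 of the 3 values shown sit, and so neither gives a direction.

In this assay no step beyond the scatter can therefore be expected with any support. The expected change, an estimate only, is a step that the limit leaves unreadable from compound 2 to compound 4 (no direction is backed by the data). For compound 4 the estimated value is 15000 nM, with an expected range from 6000 nM to 40000 nM (most likely reported only as a limit).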

Compound 4, half-maximal inhibitory concentration: 750 nM
For compound 4 the middle estimate is 20-fold (1.30 log units) above the measured one, and the stated range ends above it.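

Trifluoromethyl on an aromatic carbon, para to a large group, gives an at least 13-fold lower number from compound 2 to compound 4 (1.12 log units; beyond the scatter) in this assay, so one added group at this place can shift the number well beyond the scatter. The earlier steps shown here cannot be read, because their values are limits: the limit of > 10000 nM in this assay, at which 3 of the 4 values shown sit. Compound 3, which carries trifluoromethoxy on an aromatic carbon, reads > 10000 nM, which is a limit, so a readable value does not come from just any group on this ring.

Whether the shift is particular to trifluoromethyl stays open, since the compounds shown hold no amine, carboxylic acid or nitrile at this place. Also open, going by these compounds, is whether trifluoromethyl would give a similar step on another carbon of the same ring.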